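The compounds below may be only part of what the source reports. "The series", "measured", "known", "first", "only" and "open" are said of these compounds alone.

Compound 1, with the structure `N#CC1=C(N)OC(c2c[nH]c3ccccc23)=C(C#N)C1c1ccccc1Cl`, is one of three compounds that share a core and differ only in the aryl group attached to a saturated ring carbon. In a functional assay, tested at 200 ug/mL (on this read-out higher numbers stand for a stronger effect at the one concentration tested and lower numbers for a weaker effect), compound 1 gives 14.5%. Compound 2, `CN(C)c1ccc(C2C(C#N)=C(N)OC(c3c[nH]c4ccccc34)=C2C#N)cc1`, gives 20.5% in this assay, and compound 3, `Cc1ccc(C2C(C#N)=C(N)OC(c3c[nH]c4ccccc34)=C2C#N)cc1`, gives 6.2%. On these numbers compound 1 stands second highest of the three: the step of a number 6 percentage points higher from compound 1 to compound 2 (within the scatter) and the step of a number 8.3 percentage points lower from compound 1 to compound 3 (within the scatter) both fall inside the range of repeated measurements, so none of the three can be called the stronger or the weaker on this evidence. For the measured compounds named here, only the step of a number 14.3 percentage points lower from compound 2 to compound 3 (beyond the scatter) reaches beyond the scatter, and it is modest.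

Compound 4, `COc1ccc(C2C(C#N)=C(N)OC(c3c[nH]c4ccccc34)=C2C#N)cc1OC`, has not yet been measured. The change from compound 1 is 3,4-dimethoxyphenyl in place of 2-chlorophenyl on a saturated ring carbon. The two measured steps that bear on it, both exchanging the 2-chlorophenyl for a different aryl group on the same saturated ring carbon, were each small, which gives no ground to expect more than a small movement here. The step of a number 0.5 percentage points higher from compound 1 to compound 4 (within the scatter) is therefore expected to stay within the scatter. Compound 4 is estimated to give 15% in this assay, in a range from 5% to 28%.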

Compound 4, a percentage reported as activity, at one concentration (the size of the read-out at that concentration, not a potency): 26.1%
Estimate against measurement, compound 4: 11.1 percentage points below; low and high end bracket the measured number.
By their numbers in this assay, from the lowest: compounds 3, 1, 2 and 4 (each within the scatter of the next, the first and the last beyond it).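

In this assay, for the compounds shown here, putting 3,4-dimethoxyphenyl in place of 2-chlorophenyl gives a number 11.6 percentage points higher from compound 1 to compound 4 (beyond the scatter) and is the only step from compound 1 at this saturated ring carbon that passes the scatter, so the aryl group here can shift the read-out, though only modestly. The same group gives a number 19.9 percentage points higher from compound 3 to compound 4 (beyond the scatter) when it replaces 4-methylphenyl, but a number 5.6 percentage points higher from compound 2 to compound 4 (within the scatter) when it replaces 4-(dimethylamino)phenyl, so compound 2 and compound 4 cannot be told apart, although only compound 4 stands clear of compound 1. No measurement here explains why these aryl groups differ in this way.

A phenyl carrying a single methoxy group would show whether both methoxy groups are needed for the step from compound 1, and a phenyl carrying a carboxylic acid would test a very different kind of group at the same carbon. From the compounds shown here alone, every number also comes from one concentration, so how these compounds compare across a range of concentrations remains open.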